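Restoring an Amine Hydrogen on the Shared Core

A few compounds are considered here, and "the series" means these few. Any claim that something is new, unique, unknown or untested is made for them only; others in the source may bear on it.

Two compounds share one core. For the measured compounds named here, compound 1 `CCCNc1cc(-c2ccccc2)nc2cc(OC)cc(OC)c12` gives 1820 nM in a functional assay on LN-229 cells (Homo sapiens) for inhibition, read by MTT assay, with a stated time of 72 h (a higher number here means a weaker inhibitor, a lower number a stronger inhibitor), while compound 2 `COc1cc(OC)c2c(N3CCCCC3)cc(-c3ccccc3)nc2c1` gives 66000 nM, the higher of the two numbers; the single change between them, a 36-fold higher number from compound 1 to compound 2 (1.56 log units; beyond the scatter), was a large step. Compound 3 `COc1cc(OC)c2c(NCc3ccccc3)cc(-c3ccccc3)nc2c1` differs from compound 2 by benzylamino in place of piperidin-1-yl on an aromatic carbon, which brings back a hydrogen-bond donor of the kind compound 1 carries. Because compound 1 sits at 1820 nM, a large drop in this assay is expected, a 26-fold lower number from compound 2 to compound 3 (1.42 log units; beyond the scatter). The estimate for compound 3 is 2500 nM, with a range from 600 nM to 10000 nM.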

Compound 3, half-maximal inhibitory concentration: 7150 nM
The estimate for compound 3 lay 2.9-fold (0.46 log units) below the measured number; the range from low to high includes it.
By their numbers in this assay, from the lowest: compound 1; then compound 3; then compound 2.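

At this position, benzylamino gives (a 9.2-fold lower number from compound 2 to compound 3 (0.97 log units; beyond the scatter)) in this assay, so a second group carrying an amine hydrogen also sits well below the piperidin-1-yl compound. It does not fully match propylamino: phenyl in place of ethyl gives (a 3.9-fold higher number from compound 1 to compound 3 (0.59 log units; beyond the scatter)), so the length and nature of the chain also count.

Open, going by these compounds, is whether the amine hydrogen itself or the loss of the piperidine ring drives the gain, a question that diethylamino could help settle. No evidence on the cause of either step is available.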